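A few compounds are considered here, and "the series" means these few. Any claim that something is new, unique, unknown or untested is made for them only; others in the source may bear on it.

Compound 1 `CC1=C(C(=O)Nc2ccc(F)cc2)C(c2ccc([N+](=O)[O-])cc2)N=C(SCc2ccc(Cl)cc2)N1`: in a functional assay on the whole organism (artery, strain albino) with Rattus norvegicus as the target, with a stated time of 600 min, at a dose of 10 mg/kg by the oral route (a higher number here means more inhibition at the dose given (going by the name of the read-out), a lower number less inhibition), compound 1 gives 28.2%.
Compound 2 `CC1=C(C(=O)Nc2ccc([N+](=O)[O-])cc2)C(c2ccc(Br)cc2)N=C(SCc2ccccc2Cl)N1`: compound 2 gives 9.7%.
Compound 3 `CC1=C(C(=O)Nc2ccc([N+](=O)[O-])cc2)C(c2cccc([N+](=O)[O-])c2)N=C(SCc2ccccc2Cl)N1`: compound 3 gives 13.3%.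

Compound 3 stands second highest of the three numbers. Going by the values given here, its nearest neighbour is compound 2, and the only single-place step recorded, a number 3.6 percentage points higher from compound 2 to compound 3 (within the scatter), lies within the scatter. Compound 1 stands furthest away, with a number beyond the scatter from that of compound 3; the two structures differ in more than one place, so their two values show only that the gap exists.

The unmeasured compound 4 `CC1=C(C(=O)Nc2ccc([N+](=O)[O-])cc2)C(c2cccc([N+](=O)[O-])c2)N=C(SCc2ccc(F)cc2)N1` differs from compound 3 in one place: 4-fluorophenyl in place of 2-chlorophenyl on a saturated chain carbon bound to a sulfur. Among the compounds with values here, no measured step touches the group on the saturated chain carbon bound to a sulfur; the one recorded step, from compound 2 to compound 3, concerns a different position and was itself within the scatter. Nothing in the data therefore points to a change beyond the scatter in this assay, in either direction. Compound 4 is accordingly expected to land close to compound 3, and the step it would mean, a number 2.7 percentage points higher from compound 3 to compound 4 (within the scatter), is estimated to be small. The estimate for compound 4 is 16%, with a range from 5% to 30%.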

Compound 4, a percentage reported as inhibition, in the whole organism at one dose (the size of the read-out at that dose, not a potency): 30.3%
For compound 4 the middle estimate is 14.3 percentage points below the measured one; measured number outside the range, above it.
By their numbers in this assay, from the lowest: compounds 2 and 3 (each within the scatter of the next); then compounds 1 and 4 (each within the scatter of the next).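

In this assay, the group on the saturated chain carbon bound to a sulfur proves able to move the read-out: 4-fluorophenyl in place of 2-chlorophenyl gives a number 17 percentage points higher from compound 3 to compound 4 (beyond the scatter). Going by these compounds alone, the only earlier single-place step, a number 3.6 percentage points higher from compound 2 to compound 3 (within the scatter), concerned a saturated ring carbon and so said nothing about this position, which now provides the first single-place change in these compounds to exceed the scatter. Nothing available explains why this exchange has such an effect, so the step stands as an observation only.

The exchange alters both the halogen and the numbered ring position it occupies, so the compounds shown cannot tell whether the fluorine, its position or the loss of the chlorine accounts for the step, and a 2-fluorophenyl group at the same place would be one way to begin separating these. From the compounds shown here alone, it also remains open how this place would respond to a group without a halogen, such as an unsubstituted phenyl or a 4-methoxyphenyl, or to a longer chain in place of the aromatic ring.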